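A Flat Series Near the Limit of Its Assay

This account rests on a few compounds, and the source may have more. Where it says the series, first, only, none or still open, it means among the compounds named here.

In an ADME assay on HUVEC cells (Homo sapiens) for inhibition, read by CCK-8 assay, with a stated time of 24 h, in the presence of a further agent that is not named here (a lower number here means a stronger inhibitor, a higher number a weaker inhibitor), compound 3 (`N#Cc1ccccc1-n1cc(-c2ccc(/C=C3\C(=O)Nc4ccccc43)cc2)nn1`) gives 19700 nM and compound 1 (`O=C1Nc2ccccc2/C1=C/c1ccc(-c2cn(-c3ccccc3F)nn2)cc1`) gives 19300 nM as its nearest neighbour, the two lying within the scatter of each other. Compound 2 (`O=C1Nc2ccccc2/C1=C/c1ccc(-c2cn(-c3cccc(Cl)c3)nn2)cc1`) returns only a limit of the assay (> 20000 nM). Compound 4 (`O=C1Nc2ccccc2/C1=C/c1ccc(-c2cn(-c3ccc(Cl)c(C(F)(F)F)c3)nn2)cc1`) carries 4-chloro-3-(trifluoromethyl)phenyl in place of 2-cyanophenyl on an aromatic nitrogen. The measured steps on this group bear on the change: a 1.0-fold higher number from compound 1 to compound 3 (0.01 log units; within the scatter) and an at least 1.0-fold higher number from compound 1 to compound 2 (0.01 log units; that floor lies within the scatter) and an at least 1.0-fold lower number from compound 2 to compound 3 (0.00 log units; that floor lies within the scatter) all stay within the scatter, though the last two rest on a limit. No step beyond the scatter is therefore expected in this assay and the estimate is a 1.3-fold lower number from compound 3 to compound 4 (0.12 log units; within the scatter) in size. For compound 4 the estimated value is 15000 nM (expected range 6000 nM to 28000 nM).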

Compound 4, half-maximal inhibitory concentration: > 20000 nM
Compound 4: no number, only a limit (the forecaster's own chance of this, stated with the estimate: 40%); middle value at least 1.3-fold (0.12 log units) from the limit.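

In this assay compound 4 returns only a limit, > 20000 nM. Placing 4-chloro-3-(trifluoromethyl)phenyl on the aromatic nitrogen brings no stronger inhibition, with an at least 1.0-fold higher number from compound 3 to compound 4 (0.00 log units; that floor lies within the scatter) and an at least 1.0-fold higher number from compound 1 to compound 4 (0.01 log units; that floor lies within the scatter), while the step between compound 2 and compound 4 cannot be read. What can be read at this position is bounded by the assay itself: the limit of > 20000 nM in this assay, at which 2 of the 4 values shown sit.

Left open is how far past the limit compound 2 and compound 4 lie. Also open, on these data alone, is whether an amine or a carboxylic acid on this phenyl ring would give a number clearly lower than those of compound 1 and compound 3.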